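Swapping a Carbon Ring for an Oxygen Ring on an Amide

The source may report more compounds than this note shows. Statements on the series, on what has been measured and on what is new or still open speak of the compounds shown alone.

Three compounds share a core and differ only in the group on the ring nitrogen. Compound 1 `CC(C)(C)c1cc(NC(=O)[C@@H]2CCCCN2C2CCOCC2)no1` carries an oxan-4-yl group there and, in an ADME assay (liver) for metabolic stability, with Liver microsome (Homo sapiens) as the target, read by LC-MS, using microsomes and NADPH, tested at 1 uM (on this read-out lower numbers stand for a shorter-lived compound and higher numbers for a longer-lived compound), gives 0.317 h. Compound 2 `CC(C)(C)c1cc(NC(=O)[C@@H]2CCCCN2CC2CCOCC2)no1` carries an (oxan-4-yl)methyl group and gives 0.183 h. Compound 3 `CC(C)(C)c1cc(NC(=O)[C@@H]2CCCCN2C(=O)C2CCCCC2)no1` carries a cyclohexylcarbonyl group and gives 0.483 h, the highest of the three numbers. The measured steps are a 1.7-fold lower number from compound 1 to compound 2 (0.24 log units; within the scatter), a 1.5-fold higher number from compound 1 to compound 3 (0.18 log units; within the scatter) and a 2.6-fold higher number from compound 2 to compound 3 (0.42 log units; beyond the scatter); only the last lies beyond the scatter, and it is modest.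

Compound 4 `CC(C)(C)c1cc(NC(=O)[C@@H]2CCCCN2C(=O)C2CCOCC2)no1` keeps the carbonyl of compound 3 and changes the ring attached to it: oxan-4-yl in place of cyclohexyl on a carbonyl carbon. Within the data shown here, no measured step makes exactly this swap on a carbonyl carbon. The closest guide is the step of a 1.7-fold lower number from compound 1 to compound 2 (0.24 log units; within the scatter), where one oxane-bearing group replaced another and the number stayed within the scatter; the step of a 1.5-fold higher number from compound 1 to compound 3 (0.18 log units; within the scatter) likewise shows a carbon ring and an oxygen ring, attached in different ways, giving numbers within the scatter of each other. The step from compound 3 to compound 4 is therefore expected to be small, a 1.2-fold lower number from compound 3 to compound 4 (0.08 log units; within the scatter), with no clear direction. Compound 4 is expected to give 0.4 h, within a range from 0.2 h to 0.8 h.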

Compound 4, half-life: > 2 h
Compound 4: no number, only a limit (the forecaster's own chance of this, stated with the estimate: 5%); at least 5.0-fold (0.69 log units) between middle value and limit.
By their numbers in this assay, from the lowest: compounds 2, 1 and 3 (each within the scatter of the next, the first and the last beyond it). At a limit, above all of these: compound 4.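

On a carbonyl carbon, oxan-4-yl in place of cyclohexyl gives an at least 4.1-fold higher number from compound 3 to compound 4 (0.61 log units; beyond the scatter) and so moves the number beyond the scatter, a shift that the oxane-bearing groups on the amine nitrogen of compound 1 and compound 2 did not reveal, as those two stayed within the scatter of each other. The oxygen ring and the carbonyl appear to count only together here: with the ring kept and the carbonyl added, the record shows an at least 6.3-fold higher number from compound 1 to compound 4 (0.79 log units; beyond the scatter) and also an at least 10-fold higher number from compound 2 to compound 4 (1.03 log units; beyond the scatter) in the same direction, while compound 1, with the oxygen ring but no carbonyl, and compound 3, with the carbonyl but no oxygen ring, lie within the scatter of each other. The true size of these steps remains unknown, since compound 4 stands at a limit of the assay and not at a number: the limit of > 2 h in this assay, at which 1 of the 4 values shown sits.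

The compounds shown leave open whether the ring oxygen itself matters or whether a hydroxyl group on the cyclohexyl ring, or a ring nitrogen in a piperidin-4-yl group on the same carbonyl, would give a similar result. They also leave open why the change has this effect, as well as how long compound 4 actually lasts in this assay beyond its limit.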